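The source may report more compounds than this note shows. Statements on the series, on what has been measured and on what is new or still open speak of the compounds shown alone.

Compound 1 `O=C(CCCCC1CCSS1)Nc1ccc([N+](=O)[O-])c(C(F)(F)F)c1` reaches 51.7% in a functional assay on NCI-H460 cells (Homo sapiens) for inhibition, read by MTT assay, with a stated time of 24 h, tested at 100 ug/mL (a higher number here means more inhibition of growth at the concentration tested, a lower number less inhibition of growth), and stands second of three numbers: compound 2 `O=C(CCCCC(S)CCS)Nc1ccc(F)cc1` gives the lower 41.6% and compound 3 `O=C(CCCCC(S)CCS)Nc1ccc(OC(F)(F)F)cc1` the higher 65.1% with both gaps beyond the scatter. Compound 4 `O=C(CCCCC(S)CCS)Nc1ccc([N+](=O)[O-])c(C(F)(F)F)c1` differs from compound 1 through a group of 5 heavy atoms (3 carbon, 2 sulfur; no ring) in place of a group of 5 heavy atoms (3 carbon, 2 sulfur; one five-membered non-aromatic ring with 2 hetero atoms), on a saturated chain carbon, four bonds along the chain from a carbonyl carbon and so carries the 1,3-disulfanylpropyl group also found in compound 2 and compound 3. For the measured compounds named here, no measured step covers this change directly. Going by the values given here, the one step available, a number 23.5 percentage points higher from compound 2 to compound 3 (beyond the scatter), lies on an aromatic carbon and shows only how far compounds with this group can spread. Compound 1 falls inside that spread, so no step beyond the scatter is expected in this assay here. The estimate of a number 3.3 percentage points higher from compound 1 to compound 4 (within the scatter) is expected to stay within the scatter. Compound 4 is estimated at 55% (range 40% to 71%).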

Compound 4, percent growth inhibition at one concentration: 95.9%
Compound 4: middle estimate off by 40.9 percentage points, on the low side; measured number outside the range, above it.
By their numbers in this assay, from the lowest: compound 2; then compound 1; then compound 3; then compound 4.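

On the saturated chain carbon, four bonds along the chain from a carbonyl carbon, the 1,3-disulfanylpropyl group in place of the five-membered non-aromatic ring gives a number 44.2 percentage points higher from compound 1 to compound 4 (beyond the scatter) in this assay. The aromatic part is the same in both compounds, so this step comes from the chain end alone, where the earlier step lay on an aromatic carbon. Nothing at hand accounts for the step.

From the compounds shown here alone, whether the fluoro or trifluoromethoxy compounds show a similar gap against their ring-closed forms stays open. So does the outcome with a single thiol or a longer chain at this position.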